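The source may report more compounds than this note shows. Statements on the series, on what has been measured and on what is new or still open speak of the compounds shown alone.

Among the measured compounds shown here, compound 2 `Cn1cc(C(=O)CCCCc2ccccc2)cc1/C=C/C(=O)NO` stands at the higher of the two numbers measured so far: in an assay on isolated protein for inhibition of histone deacetylase HD2 (Zea mays) (on this read-out lower numbers stand for stronger inhibition and higher numbers for weaker inhibition), compound 2 gives 110 nM, while compound 1 `Cn1cc(C(=O)CCc2ccccc2)cc1/C=C/C(=O)NO` gives 43 nM. For the measured compounds named here, the single step that bears on the next change is a 2.6-fold higher number from compound 1 to compound 2 (0.41 log units; beyond the scatter), a modest weakening as the chain grew. Compound 3 `Cn1cc(C(=O)CCCCCCCc2ccccc2)cc1/C=C/C(=O)NO` carries 3-phenylpropyl in place of phenyl on a saturated chain carbon, four bonds along the chain from a carbonyl carbon, a longer extension of the same chain. The earlier step suggests a further rise in the number is expected, likely of similar or somewhat larger size, as a 2.5-fold higher number from compound 2 to compound 3 (0.41 log units; beyond the scatter). Compound 3 is accordingly estimated at 280 nM, within a range of 110 nM to 800 nM.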

Compound 3, half-maximal inhibitory concentration: 209 nM
The estimate for compound 3 lay 1.3-fold (0.13 log units) above the measured number; the measured number falls inside the stated range.
By their numbers in this assay, from the lowest: compound 1; then compounds 2 and 3 (each within the scatter of the next).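

In this assay, the change from phenyl to 3-phenylpropyl, on a saturated chain carbon, four bonds along the chain from a carbonyl carbon, gives a 1.9-fold higher number from compound 2 to compound 3 (0.28 log units; within the scatter) and so cannot be read as a real difference. The step beyond the scatter seen earlier therefore does not recur as a separate step at this longer chain length. Nothing available explains this flattening. Still open, on these data alone, is whether a longer chain would keep the number within the scatter of compound 3, and whether an amine or a carboxylic acid at the end of the chain would shift it.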